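This account rests on a few compounds, and the source may have more. Where it says the series, first, only, none or still open, it means among the compounds named here.

Compound 1 `Cc1ccc2c(c1)C[C@@H](O)C[C@@H](c1ccccc1Cl)N2`: 82400 nM
Compound 2 `O[C@@H]1Cc2cc(Cl)ccc2N[C@H](c2ccccc2Cl)C1`: 106000 nM
Compound 3 `O[C@@H]1Cc2cc(Cl)ccc2N[C@H](c2ccccc2F)C1`: 182000 nM

These three compounds share one core and were all tested in an ADME assay on Vero cells (Chlorocebus sabaeus) for cytotoxicity, read by MTT assay, with a stated time of 72 h; a higher number here means that more compound is tolerated, a lower number that less compound is tolerated. Their numbers lie close together. One step is a 1.3-fold higher number from compound 1 to compound 2 (0.11 log units; within the scatter) and the next is a 1.7-fold higher number from compound 2 to compound 3 (0.23 log units; within the scatter); neither is large enough to count as a real difference, so on this assay compound 2 cannot be told apart from either neighbour.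

The next compound, compound 4 `O[C@@H]1Cc2cc(Cl)ccc2N[C@H](c2c(Cl)cccc2Cl)C1`, is reached from compound 2 by a single change: chloro in place of hydrogen on an aromatic carbon. The new chloro group sits ortho to a large group and meta to a chloro group on a six-membered aromatic ring of carbon only.

The two measured steps that resemble this change are both small changes at an aromatic carbon: a 1.3-fold higher number from compound 1 to compound 2 (0.11 log units; within the scatter) and a 1.7-fold higher number from compound 2 to compound 3 (0.23 log units; within the scatter). Both fell within the scatter. On that basis the step from compound 2 to compound 4 is expected to stay within the scatter as well, with no clear direction.

The number for compound 4 in this assay is therefore estimated at 95000 nM, in a range from 45000 nM to 200000 nM, which corresponds to an expected step of a 1.1-fold lower number from compound 2 to compound 4 (0.05 log units; within the scatter).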

Compound 4, half-maximal cytotoxic concentration: 49900 nM
Beside the measured number, compound 4's estimate is 1.9-fold (0.28 log units) above it; the measured number falls inside the stated range.
By their numbers in this assay, from the lowest: compounds 4, 1, 2 and 3 (each within the scatter of the next, the first and the last beyond it).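

Putting a chloro group where a hydrogen stood, on the aromatic carbon ortho to a large group and meta to a chloro group, gives a 2.1-fold lower number from compound 2 to compound 4 (0.33 log units; beyond the scatter) in this assay. This is the first step among these compounds to pass the usual scatter, though only modestly, and it is also a different kind of change: the two earlier steps swapped one group on an aromatic carbon for another, whereas this one places a group on a carbon that carried only hydrogen. The result therefore marks this position as one where adding a chloro group can lower the tolerated concentration, but nothing available explains the drop.

The compounds shown leave open whether an amine, a methoxy group or a carboxylic acid in place of the same hydrogen would move the number in the same direction or stay within the scatter. From the compounds shown here alone, it is also open whether a chloro group on another carbon of this ring would do the same, and a single step cannot separate the effect of the group from that of its place.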